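Series notes: compound 4, the imidazolyl analogue

This account rests on a few compounds, and the source may have more. Where it says the series, first, only, none or still open, it means among the compounds named here.

Going by the values given here, compound 3 `OCc1nnc(-c2ccc(N3CCC(Oc4ccccc4C(F)(F)F)CC3)nn2)s1` gives 3.2 nM in an assay on microsomes from liver for inhibition of acyl-CoA desaturase 1 (Rattus norvegicus) (on this read-out higher numbers stand for weaker inhibition and lower numbers for stronger inhibition), the lowest of the three numbers measured so far. Compound 2 `Brc1ccccc1OC1CCN(c2ccc(-n3ccnc3)nn2)CC1` gives 5 nM in this assay, within the scatter of compound 3, while compound 1 `O=C(NCCC1CC1)c1ccc(N2CCC(Oc3ccccc3C(F)(F)F)CC2)nn1` gives 14 nM, beyond it. Among the compounds with values here, the only measured step at this position, a 4.4-fold lower number from compound 1 to compound 3 (0.64 log units; beyond the scatter), shows that exchanging the group on that aromatic carbon can shift the number by a modest amount. Compound 4 `FC(F)(F)c1ccccc1OC1CCN(c2ccc(-n3ccnc3)nn2)CC1` differs from compound 3 by 1H-imidazol-1-yl in place of 5-(hydroxymethyl)-1,3,4-thiadiazol-2-yl on an aromatic carbon. Within the data shown here, no measured step covers this exact exchange; compound 2 carries the same imidazolyl group on the shared core but differs from compound 3 in a second place as well, and its value and that of compound 3 lie within the scatter of each other. For compound 4 the expected step is therefore small, a 1.3-fold higher number from compound 3 to compound 4 (0.10 log units; within the scatter), with no direction claimed beyond the scatter. Compound 4 is estimated at 4 nM in this assay, with a range from 1.5 nM to 12 nM.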

Compound 4, half-maximal inhibitory concentration: 4 nM
Estimate against measurement, compound 4: no gap at the digits printed; measured number inside the range.
By their numbers in this assay, from the lowest: compounds 3, 4 and 2 (each within the scatter of the next); then compound 1.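

In this assay the exchange of 5-(hydroxymethyl)-1,3,4-thiadiazol-2-yl for 1H-imidazol-1-yl on this aromatic carbon (a 1.3-fold higher number from compound 3 to compound 4 (0.10 log units; within the scatter)) stays within the scatter, so this read-out does not separate these two five-membered aromatic rings, despite their different counts of donors and acceptors. Both rings stand apart from (2-cyclopropylethyl)carbamoyl at this position, since 1H-imidazol-1-yl (a 3.5-fold lower number from compound 1 to compound 4 (0.54 log units; beyond the scatter)) and 5-(hydroxymethyl)-1,3,4-thiadiazol-2-yl (a 4.4-fold lower number from compound 1 to compound 3 (0.64 log units; beyond the scatter)) each give a step beyond the scatter. At the other place of change, trifluoromethyl in place of bromo (a 1.3-fold lower number from compound 2 to compound 4 (0.10 log units; within the scatter)) is also within the scatter, and no evidence on the cause of any of these steps is at hand.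

Open, from the compounds shown here alone, is whether an amine or a carboxylic acid on this aromatic carbon would stay with the two rings or with the carbamoyl group. Also open, going by these compounds, is whether a chloro or methoxy group in place of trifluoromethyl would leave the number equally unmoved.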